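Swapping a bicyclic sulfur-linked group for a bromophenyl

The source may report more compounds than this note shows. Statements on the series, on what has been measured and on what is new or still open speak of the compounds shown alone.

Measured compounds:
Compound 1 `Cc1cc(N2CC[C@@H](C)[C@@H](N(C)c3ncnc4[nH]ccc34)C2)n2nc(SCc3nc4ccccc4[nH]3)nc2n1`: 21200 nM
Compound 2 `Cc1cc(N2CC[C@@H](C)[C@@H](N(C)c3ncnc4[nH]ccc34)C2)n2nc(SCc3csc4ccc(Cl)cc34)nc2n1`: > 100000 nM
Compound 3 `Cc1cc(N2CC[C@@H](C)[C@@H](N(C)c3ncnc4[nH]ccc34)C2)n2nc(SCc3ccc(F)cc3)nc2n1`: 11900 nM

In a functional assay on MGC-803 cells (Homo sapiens) for inhibition, read by MTT assay, with a stated time of 72 h (a higher number here means a weaker inhibitor, a lower number a stronger inhibitor), compound 2 gives only a limit, > 100000 nM, and no number. Among the three measured compounds it is the one for which this assay reports no value at all, as the line the limit of > 100000 nM in this assay, at which 1 of the 3 values shown sits, shows. Compound 1 gives 21200 nM and compound 3 gives 11900 nM in this assay; these two values lie within the scatter of each other, a 1.8-fold lower number from compound 1 to compound 3 (0.25 log units; within the scatter).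

Compound 4 `Cc1cc(N2CC[C@@H](C)[C@@H](N(C)c3ncnc4[nH]ccc34)C2)n2nc(SCc3ccc(Br)cc3)nc2n1` differs from compound 2 in one place: 4-bromophenyl in place of 5-chloro-1-benzothiophen-3-yl on a saturated chain carbon bound to a sulfur. Among the measured compounds shown here, the closest measured step is the one from compound 2 to compound 3, where a 4-fluorophenyl took the place of the same bicyclic group and gave an at least 8.4-fold lower number from compound 2 to compound 3 (0.92 log units; beyond the scatter). The step from compound 1 to compound 2 ran the other way, an at least 4.7-fold higher number from compound 1 to compound 2 (0.67 log units; beyond the scatter).

A 4-bromophenyl resembles the 4-fluorophenyl of compound 3, so compound 4 is expected to land near compound 3, and the expected step is an at least 6.6-fold lower number from compound 2 to compound 4 (0.82 log units; beyond the scatter). The estimated value for compound 4 in this assay is 15000 nM, with an expected range from 6000 nM to 45000 nM.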

Compound 4, half-maximal inhibitory concentration: 4020 nM
Compound 4: the middle estimate sits 3.7-fold (0.57 log units) above what was measured; measured number below the stated range.
By their numbers in this assay, from the lowest: compound 4; then compounds 3 and 1 (each within the scatter of the next). At a limit, above all of these: compound 2.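

In this assay, among the compounds shown here, bromo in place of fluoro on an aromatic carbon gives a 3.0-fold lower number from compound 3 to compound 4 (0.47 log units; beyond the scatter), so the choice of halogen on this sulfur-linked phenyl ring changes the result, which the earlier compounds could not show. The 4-bromophenyl also stands clear of the 1H-benzimidazol-2-yl, with a 5.3-fold lower number from compound 1 to compound 4 (0.72 log units; beyond the scatter), and of the 5-chloro-1-benzothiophen-3-yl, with an at least 24-fold lower number from compound 2 to compound 4 (1.39 log units; beyond the scatter). That last step has no fixed size, as compound 2 gives only a limit of the assay: the limit of > 100000 nM in this assay, at which 1 of the 4 values shown sits.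

As far as these compounds go, with only two halogens to compare, it stays open whether a 4-chlorophenyl would fall between compound 3 and compound 4, or whether a 4-methoxyphenyl or a carboxylic acid on the same ring would keep the gain. The compounds shown also give no reason why bromo outdoes fluoro here.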